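An aromatic ring returns on the amide of compound 3

This account rests on a few compounds, and the source may have more. Where it says the series, first, only, none or still open, it means among the compounds named here.

Compound 1, `CCCCNc1nc(N)nc2c1CN(Cc1ccccc1)CC2`: 0.06 uM
Compound 2, `CCCCNc1nc(N)nc2c1CN(Cc1cccnc1)CC2`: 0.13 uM
Compound 3, `CCCCNc1nc(N)nc2c1CN(C(=O)CC)CC2`: 0.4 uM

In an assay on HEK293 cells for agonist activity at Toll-like receptor 8 (Homo sapiens), read by a luciferase reporter, with a stated time of 6 h (a lower number here means that less compound is needed, a higher number that more compound is needed for the effect), compound 3 stands at the highest number of the three: there is a 3.1-fold higher number from compound 2 to compound 3 (0.49 log units; beyond the scatter) and a 6.7-fold higher number from compound 1 to compound 3 (0.82 log units; beyond the scatter), so compound 3 needs the most compound for the effect. Compound 4, `CCCCNc1nc(N)nc2c1CN(C(=O)c1csc(C)n1)CC2`, differs from compound 3 in one place only: 2-methyl-1,3-thiazol-4-yl in place of ethyl on a carbonyl carbon.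

Among the measured compounds shown here, no measured step changes exactly this part of the molecule. The steps that come closest are those in which a benzyl or a (pyridin-3-yl)methyl group on the ring nitrogen gave way to propanoyl, a 6.7-fold higher number from compound 1 to compound 3 (0.82 log units; beyond the scatter) and a 3.1-fold higher number from compound 2 to compound 3 (0.49 log units; beyond the scatter); both times the loss of the aromatic ring raised the number. The step of a 2.2-fold higher number from compound 1 to compound 2 (0.34 log units; beyond the scatter) shows that a pyridin-3-yl in place of phenyl raised the number modestly, so a ring carrying hetero atoms was somewhat weaker than a plain one. Compound 4 brings a small aromatic ring back, though attached to the carbonyl carbon rather than to a saturated chain carbon. Compound 4 is therefore expected to show a modestly lower number, a 2.0-fold lower number from compound 3 to compound 4 (0.30 log units; within the scatter). In this assay, compound 4 is estimated at 0.2 uM, most likely between 0.07 uM and 0.6 uM.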

Compound 4, minimum effective concentration: 1.8 uM
Compound 4: middle estimate off by 9.0-fold (0.95 log units), on the low side, outside the stated range (above it).
By their numbers in this assay, from the lowest: compound 1; then compound 2; then compound 3; then compound 4.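

In this assay, an aromatic ring on the carbonyl carbon does not lower the number; the 2-methyl-1,3-thiazol-4-yl in place of ethyl raises it (a 4.5-fold higher number from compound 3 to compound 4 (0.65 log units; beyond the scatter)). The gap is wider against the compounds whose ring nitrogen carries a saturated chain carbon rather than a carbonyl (a 14-fold higher number from compound 2 to compound 4 (1.14 log units; beyond the scatter); a 30-fold higher number from compound 1 to compound 4 (1.48 log units; beyond the scatter)), and both of these steps are large. So among these compounds, an aromatic ring in the group on the ring nitrogen does not by itself give a low number: compound 1 and compound 2 have one and sit lowest, whereas compound 4 also has one and sits highest, above compound 3, which has none.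

Nothing available explains this rise. The compounds shown leave open whether the high number of compound 4 belongs to this particular ring or to any large group on the carbonyl carbon, and a benzoyl group on the ring nitrogen, or a (2-methyl-1,3-thiazol-4-yl)methyl group there, would help separate the ring from the carbonyl that links it.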